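The compounds below may be only part of what the source reports. "The series", "measured", "known", "first", "only" and "open" are said of these compounds alone.

Compound 1 `Oc1ccc(C2=NN(c3ccc(Cl)cc3)C(c3ccc(Cl)cc3)C2)c(O)c1` was tested in an assay on HEK293 cells for inhibition of protein kinase C iota type (Homo sapiens), read by 33P incorporation, with a stated time of 40 min, tested at 20 uM, in the presence of a further agent that is not named here (on this read-out higher numbers stand for more inhibition at the one concentration tested (going by the name of the read-out) and lower numbers for less inhibition), and gives 14.9%. Two near relatives were measured alongside it: compound 2 `Oc1ccc(C2=NN(c3ccc(Cl)cc3)C(c3cccc(Cl)c3)C2)cc1` gives 18.6% in this assay, and compound 3 `Oc1ccc(C2=NN(c3cccc(Cl)c3)C(c3ccc(Cl)cc3)C2)cc1` gives 22.8%. Compound 1 sits at the low end of these three numbers, but the gaps to compound 2 and to compound 3 both fall within the usual scatter of such measurements, so the three cannot be told apart with confidence. All three show only modest inhibition at the single concentration used.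

Compound 4 `Oc1cccc(C2=NN(c3ccc(Cl)cc3)C(c3ccc(Cl)cc3)C2)c1` has not been measured in this assay. Relative to compound 1 it differs in one place: 3-hydroxyphenyl in place of 2,4-dihydroxyphenyl on a carbon with a double bond to nitrogen. Among the compounds with values here, no pair of measured compounds differing in exactly one place is available, so the size of this change cannot be read from a neighbouring step. Given that compound 1 gives 14.9% and that the three measured numbers all sit in the same low band, compound 4 is expected to stay in that band, with an expected step of a number 2.1 percentage points higher from compound 1 to compound 4 (within the scatter) not beyond the scatter. For compound 4 the estimate in this assay is 17%, with a range from 4% to 30%.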

Compound 4, a percentage reported as inhibition, at one concentration (the size of the read-out at that concentration, not a potency): 9.3%
For compound 4 the middle estimate is 7.7 percentage points above the measured one; low and high end bracket the measured number.
By their numbers in this assay, from the lowest: compounds 4, 1, 2 and 3 (each within the scatter of the next, the first and the last beyond it).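

In this assay, within the data shown here, the first one-place change at this position, 3-hydroxyphenyl in place of 2,4-dihydroxyphenyl, gives a number 5.6 percentage points lower from compound 1 to compound 4 (within the scatter) and so does not separate the two compounds. The group that enters has fewer hydrogen-bond donors and acceptors than the one that leaves, yet inhibition stays in the same low band, so this particular change at this position has no effect that can be told from the scatter. No measurement at hand offers an explanation for the step.

The compounds shown do not settle whether a single hydroxyl placed elsewhere on this ring would behave the same way. Going by these compounds, it also remains open whether an amine or a carboxylic acid in place of the hydroxyl would move the number out of this low band.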